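The compounds below may be only part of what the source reports. "The series", "measured", "known", "first", "only" and "open" are said of these compounds alone.

Measured in an ADME assay on microsomes from liver (Homo sapiens) for metabolic stability, read by LC-MS, using NADPH, with stated times of 5 min and 30 min, tested at 1 uM; a higher number here means faster removal of the compound, a lower number slower removal:
compound 1 `Cc1nccn1-c1cnc(NCc2c(F)ccc3c2CCO3)c2cn[nH]c(=O)c12` gives 8 mL.min-1.g-1
compound 2 `O=C(Nc1cnc(NCc2c(F)ccc3c2CCO3)n2cnnc12)c1ccccc1` gives 10 mL.min-1.g-1
compound 3 `Cc1nc(CN(C)C)ccc1-c1cnc(NCc2c(F)ccc3c2CCO3)c2cn[nH]c(=O)c12` gives 13 mL.min-1.g-1

On the numbers alone compound 3 sits at the top of the three, but its gap to compound 2 and its gap to compound 1 both lie within the scatter, so the three compounds are not separated in this assay. For the measured compounds named here, the only single-site step among them, a 1.6-fold higher number from compound 1 to compound 3 (0.21 log units; within the scatter), is also within the scatter.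

Compound 4 `Cc1nc(CO)ccc1-c1cnc(NCc2c(F)ccc3c2CCO3)c2cn[nH]c(=O)c12` differs from compound 3 in one place: hydroxy in place of dimethylamino on a saturated chain carbon bound to an aromatic carbon. Going by the values given here, no measured pair shows this exchange. Among the compounds with values here, the one step that exists, a 1.6-fold higher number from compound 1 to compound 3 (0.21 log units; within the scatter), touches the same aromatic ring but replaces a different group, so it bears on compound 4 only in showing that a substituent exchange there left the number within the scatter. For compound 4 the step of a 1.3-fold lower number from compound 3 to compound 4 (0.11 log units; within the scatter) is therefore expected to stay within the scatter, with no clear direction. Compound 4 is estimated at 10 mL.min-1.g-1, with a range from 5 mL.min-1.g-1 to 20 mL.min-1.g-1.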

Compound 4, intrinsic clearance in microsomes: 11 mL.min-1.g-1
For compound 4 the middle estimate is 1.1-fold (0.04 log units) below the measured one; the range from low to high includes it.
By their numbers in this assay, from the lowest: compounds 1, 2, 4 and 3 (each within the scatter of the next).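

In this assay, for the compounds shown here, hydroxy in place of dimethylamino on a saturated chain carbon bound to an aromatic carbon gives a 1.2-fold lower number from compound 3 to compound 4 (0.07 log units; within the scatter), so this exchange, absent from the earlier pairs, does not separate the two compounds. Replacing 2-methyl-1H-imidazol-1-yl on an aromatic carbon with 6-(hydroxymethyl)-2-methylpyridin-3-yl gives a 1.4-fold higher number from compound 1 to compound 4 (0.14 log units; within the scatter), which adds a second group to the step of a 1.6-fold higher number from compound 1 to compound 3 (0.21 log units; within the scatter), and compounds 1, 3 and 4 remain unresolved from one another. No measurement at hand offers an explanation for these steps.

Still open, from the compounds shown here alone, is whether a carboxylic acid, a primary amine or a longer chain in place of hydroxy on that carbon would give a step beyond the scatter. Going by these compounds, whether the exchange from dimethylamino to hydroxy behaves the same way on another core also remains open.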